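Benzyl in Place of Cyclohexyl: Expected Cell Growth Inhibition

This account rests on a few compounds, and the source may have more. Where it says the series, first, only, none or still open, it means among the compounds named here.

Measured compounds:
Compound 1 `c1ccc2c(-c3cn4ccnc4c(-c4ccc5ncn(C6CCCCC6)c5c4)n3)cccc2c1`: 6.49%
Compound 2 `c1ccc(Cn2cnc3ccc(-c4nc(-c5cccc6ccccc56)cn5ccnc45)cc32)cc1`: 12.4%
Compound 3 `c1cn2cc(-c3ccc4c(c3)ncn4C3CCCCC3)nc(-c3ccc4ncn(C5CCCCC5)c4c3)c2n1`: 5.48%

All three were tested in a functional assay on ACHN cells (Homo sapiens) for inhibition, read by sulforhodamine B assay, with a stated time of 48 h, tested at 10 uM; on this read-out higher numbers stand for more inhibition at the one concentration tested (going by the name of the read-out) and lower numbers for less inhibition. Compound 3 has the lowest of the three numbers, but its distances to compound 1 and to compound 2 both lie within the scatter, so no order among them can be read. Compound 1 and compound 2 differ in one place: benzyl in place of cyclohexyl on an aromatic nitrogen. That change gave a number 5.9 percentage points higher from compound 1 to compound 2 (within the scatter), a step within the scatter. How the core of compound 3 differs from the core of compound 1 is not broken down here.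

Compound 4 `c1ccc(Cn2cnc3ccc(-c4nc(-c5ccc6c(c5)ncn6C5CCCCC5)cn5ccnc45)cc32)cc1` is not yet measured. It arises from compound 3 by the same change: benzyl in place of cyclohexyl on an aromatic nitrogen. Because the earlier step, a number 5.9 percentage points higher from compound 1 to compound 2 (within the scatter), was small, a similarly small step is expected here, namely a number 5.5 percentage points higher from compound 3 to compound 4 (within the scatter). Compound 4 is therefore estimated to give 11% in this assay, with a range from 0% to 25% expected to hold most repeat measurements.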

Compound 4, a percentage reported as inhibition, at one concentration (the size of the read-out at that concentration, not a potency): 80.1%
Estimate against measurement, compound 4: 69.1 percentage points below; measured number outside the range, above it.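

In this assay, benzyl in place of cyclohexyl on an aromatic nitrogen gave a number 74.6 percentage points higher from compound 3 to compound 4 (beyond the scatter), a far larger result than the same change gave on the other core. The effect of this change therefore did not carry over unchanged between these two cores, and its size depended on the core that carried it: the same change on two cores in this assay, a number 5.9 percentage points higher (within the scatter) from compound 1 to compound 2 and a number 74.6 percentage points higher (beyond the scatter) from compound 3 to compound 4, 68.7 percentage points apart, beyond the scatter of two such steps. These two pairs do not show which part of the cores accounts for the difference, nor how large the step would be on any third core.

Only benzyl and cyclohexyl appear on this nitrogen here, leaving open how a longer chain or a group bearing an amine would behave in the same place on either core. Also open, going by these compounds, is whether the large step depends on the cyclohexyl that remains in compound 4, as a close analogue carrying another group in its place would be needed to tell.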